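A tert-Butyl Analogue Assessed Against Three Limit Values

A few compounds are considered here, and "the series" means these few. Any claim that something is new, unique, unknown or untested is made for them only; others in the source may bear on it.

Compound 3 `CCC1(Cc2ccccc2)OS(=O)(=O)C=C1OCc1ccc(C(F)(F)F)cc1` stands among three measured compounds in an ADME assay on HEL cells (Homo sapiens) for cytotoxicity, with a stated time of 3 days; on this read-out lower numbers stand for higher toxicity in this test and higher numbers for lower toxicity in this test. In this assay compound 3 gives only a limit, >= 16000 nM, as recorded in the limit of >= 16000 nM in this assay, at which 1 of the 3 values shown sits. Compound 1 `CCC1(Cc2ccccc2)OS(=O)(=O)C=C1OCc1ccc(F)cc1` likewise gives only a limit in this assay, >= 50000 nM, shown in the limit of >= 50000 nM in this assay, at which 1 of the 3 values shown sits. Compound 2 `CCC1(Cc2ccccc2)OS(=O)(=O)C=C1OCc1ccc(OC)cc1` also gives only a limit in this assay, >= 200000 nM, shown in the limit of >= 200000 nM in this assay, at which 1 of the 3 values shown sits. Each of these values is a limit, so none of the steps among them can be sized: a step that the two limits leave unreadable from compound 1 to compound 2, a step that the two limits leave unreadable from compound 1 to compound 3 and a step that the two limits leave unreadable from compound 2 to compound 3 all remain unreadable.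

Compound 4 `CCC1(Cc2ccccc2)OS(=O)(=O)C=C1OCc1ccc(C(C)(C)C)cc1` differs from compound 3 by tert-butyl in place of trifluoromethyl on an aromatic carbon. Among the measured compounds shown here, no measured step bears on this change, and the three unreadable steps offer no size in either direction. The expected step that the limit leaves unreadable from compound 3 to compound 4 is therefore set near no change beyond the scatter. Compound 4 is estimated at 30000 nM, within 8000 nM to 200000 nM, with a good chance that this assay again reports only a limit.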

Compound 4, minimum cytotoxic concentration: >= 400000 nM
Compound 4: a limit, no number; the forecaster's own chance of this, stated with the estimate: 70%; middle value at least 13-fold (1.12 log units) away from the limit.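

Among the compounds shown here, compound 4 gives only a limit, as do compound 1, compound 2 and compound 3, so no step from any of these to compound 4 can be read. The compounds shown leave open the actual minimum cytotoxic concentration of all four, and so how far exchanging the group on the aromatic carbon shifts it.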